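A few compounds are considered here, and "the series" means these few. Any claim that something is new, unique, unknown or untested is made for them only; others in the source may bear on it.

Compound 1 `O=C(NO)c1ccc(-c2cn([C@@H]3C[C@@H](C(=O)O)N(Cc4ccccc4)C3)nn2)cc1` is one of three stereoisomers that share every atom and bond and differ only in how two ring carbons are drawn. In an assay on Sf9 cells for inhibition of histone deacetylase 11 (Homo sapiens), read by fluorescence, tested at 0.5 uM (on this read-out lower numbers stand for less inhibition and higher numbers for more inhibition at the one concentration tested (going by the name of the read-out)), compound 1 gives < 10%, which is a limit of the assay rather than a number. Compound 2 `O=C(NO)c1ccc(-c2cn([C@@H]3C[C@H](C(=O)O)N(Cc4ccccc4)C3)nn2)cc1` gives < 10%, again a limit. Compound 3 `O=C(NO)c1ccc(-c2cn([C@H]3C[C@@H](C(=O)O)N(Cc4ccccc4)C3)nn2)cc1` gives < 10%, also a limit. The steps between them, a step that the two limits leave unreadable from compound 1 to compound 2 and a step that the two limits leave unreadable from compound 1 to compound 3 and a step that the two limits leave unreadable from compound 2 to compound 3, therefore cannot be sized; all that is known is that the three isomers sit together at the limit (the limit of < 10% in this assay, at which 3 of the 3 values shown sit).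

Compound 4 `O=C(/C=C/c1cn([C@@H]2C[C@@H](C(=O)O)N(Cc3ccccc3)C2)nn1)NO` keeps the configuration of compound 1 but changes the group on the five-membered aromatic ring: 2-(hydroxycarbamoyl)ethenyl in place of 4-(hydroxycarbamoyl)phenyl on an aromatic carbon. Among the measured compounds shown here, none of the measured steps touches this kind of change; they concern only configuration, and each is unreadable. For the measured compounds named here, the only guidance is that every measured isomer sits at the limit (the limit of < 10% in this assay, at which 3 of the 3 values shown sit), so compound 4 is expected to stay in the same low region, with a step that the limit leaves unreadable from compound 1 to compound 4 expected to be no more than the scatter. For compound 4 the estimate is 8%, within a range from 0% to 25%.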

Compound 4, a percentage reported as inhibition, at one concentration (the size of the read-out at that concentration, not a potency): 12%
Beside the measured number, compound 4's estimate is 4 percentage points below it; the range from low to high includes it.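

Compound 4 is the only compound here that gives a number rather than a limit in this assay: the limit of < 10% in this assay, at which 3 of the 4 values shown sit.

Among the compounds shown here, replacing 4-(hydroxycarbamoyl)phenyl with 2-(hydroxycarbamoyl)ethenyl on this aromatic carbon of the five-membered ring gives a number at least 2 percentage points higher from compound 1 to compound 4 (that floor lies within the scatter), so the first readable step concerns this group and not configuration, whose steps all remain unreadable. The change removes the six-membered aromatic ring and keeps the hydroxycarbamoyl group, yet inhibition at the one concentration tested stays low, and the floor of the step gives no firm evidence of a real gain.

On these data alone, what a longer chain ending in the hydroxycarbamoyl group would do at this aromatic carbon remains open, as does the effect of an amine in place of the hydroxycarbamoyl group. The compounds shown also leave open whether 2-(hydroxycarbamoyl)ethenyl would give a similar reading on the other two configurations of the core, since it appears here only with the configuration of compound 1.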